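A few compounds are considered here, and "the series" means these few. Any claim that something is new, unique, unknown or untested is made for them only; others in the source may bear on it.

In a functional assay on CCRF-CEM cells (Homo sapiens) for inhibition (on this read-out higher numbers stand for weaker inhibition and lower numbers for stronger inhibition), compound 3 (`O=C1CCCCC/C1=C\c1ccc(F)cc1`) gives 198000 nM. Compound 2 (`O=C1CCCCC/C1=C\c1cccc(F)c1`) gives 224000 nM, which lies within the scatter of compound 3, so the two cannot be told apart on this read-out. Compound 1 (`O=C1/C(=C/c2ccc(F)cc2)Cc2ccccc21`) gives 42200 nM, a number clearly lower than that of compound 3, and so compound 3 stands with compound 2 at the weak end of this small set.

The next compound, compound 4 (`CN(C)c1ccc(/C=C2\CCCCCC2=O)cc1`), carries dimethylamino in place of fluoro on an aromatic carbon. For the measured compounds named here, no measured pair in the set differs in one place only, so the data offer no direct guide to this change. The estimate therefore stays close to compound 3 at 198000 nM. The expected move, a 1.3-fold lower number from compound 3 to compound 4 (0.12 log units; within the scatter), is a slight shift towards stronger inhibition, not expected to exceed the scatter in this assay. For compound 4 the estimated value is 150000 nM, with an expected range from 50000 nM to 320000 nM.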

Compound 4, half-maximal inhibitory concentration: 45100 nM
For compound 4 the middle estimate is 3.3-fold (0.52 log units) above the measured one; the measured number lies below the stated range.
By their numbers in this assay, from the lowest: compounds 1 and 4 (each within the scatter of the next); then compounds 3 and 2 (each within the scatter of the next).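

For the compounds shown here, replacing fluoro with dimethylamino on this aromatic carbon gives a 4.4-fold lower number from compound 3 to compound 4 (0.64 log units; beyond the scatter) in this assay and is the first change in one place that can be read in this set. The step lies beyond the scatter and moves towards stronger inhibition, so this position, on a six-membered aromatic ring of carbon only, does respond to the group it carries. No measurement shown here bears on the cause of this step.

The compounds shown leave open whether the step follows the nitrogen of the new group or its greater count of heavy atoms, and how a methoxy group or a plain amino group would read in the same place. Also open, as far as these compounds go, is whether the same replacement would move the number in the same way on the core of compound 1.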